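A few compounds are considered here, and "the series" means these few. Any claim that something is new, unique, unknown or untested is made for them only; others in the source may bear on it.

Compound 1 `CC(C)C[C@H](NC(=O)N1CCOCC1)C(=O)N[C@H](C#N)CCc1ccccc1`: 47 nM
Compound 2 `CC(C)C[C@H](NC(=O)N1CCOCC1)C(=O)NCC#N`: 124 nM
Compound 3 `CC(C)[C@H](NC(=O)N1CCOCC1)C(=O)N[C@H](C#N)CCc1ccccc1`: 6000 nM

These three compounds have been measured in an assay for inhibition of cathepsin S (Homo sapiens); on this read-out higher numbers stand for weaker inhibition and lower numbers for stronger inhibition. On these numbers compound 3 stands highest of the three and is thus the weakest inhibitor shown; compound 2 is the nearest to it and compound 1 the furthest.

Compound 4 `N#C[C@H](CCc1ccccc1)NC(=O)[C@@H](NC(=O)N1CCOCC1)C1CCCCC1` is the next step from compound 3: cyclohexyl in place of isopropyl on a saturated chain carbon bound to an amide-type nitrogen and a carbonyl carbon. Two measured steps can be weighed. The step of a 2.6-fold higher number from compound 1 to compound 2 (0.42 log units; beyond the scatter) changes a different place in the molecule and says little about this one. The step of a 130-fold higher number from compound 1 to compound 3 (2.11 log units; beyond the scatter) changes exactly the place altered here and shows that the group at this position shifts the number strongly. For the measured compounds named here, no measured compound carries cyclohexyl at this place, so the direction of the new step rests on inference: a position that responded so sharply once is more likely to move the number again than to leave it where compound 3 stands, and the larger group is more likely to bring the number back toward compound 1 than to push it further up.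

Compound 4 is therefore expected to give a lower number, with the step estimated as a 24-fold lower number from compound 3 to compound 4 (1.38 log units; beyond the scatter). The estimate for compound 4 in this assay is 250 nM, within a range from 40 nM to 1500 nM.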

Compound 4, half-maximal inhibitory concentration: 84 nM
Beside the measured number, compound 4's estimate is 3.0-fold (0.47 log units) above it; low and high end bracket the measured number.
By their numbers in this assay, from the lowest: compounds 1, 4 and 2 (each within the scatter of the next, the first and the last beyond it); then compound 3.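

At this place in this assay, cyclohexyl in place of isopropyl brings a 71-fold lower number from compound 3 to compound 4 (1.85 log units; beyond the scatter) and shows that the position can swing strongly downward as well as upward, whereas the earlier compounds had shown only a sharp rise on going from isobutyl to isopropyl. Set against isobutyl, cyclohexyl gives a 1.8-fold higher number from compound 1 to compound 4 (0.25 log units; within the scatter) and the two numbers cannot be told apart, so a good number here does not depend on isobutyl alone: a six-membered ring of carbon only does as well, and among these three groups the high number of compound 3 belongs to isopropyl. Nothing available explains why these groups rank as they do.

On these data alone, whether the same holds for an aromatic ring such as phenyl, for a longer chain such as n-butyl, or for a six-membered ring that carries an oxygen, such as tetrahydropyranyl, remains open. It is also open whether cyclohexyl would keep its number with hydrogen in place of phenethyl, the other change seen in this series, since the two changes appear together in no compound shown.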